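Notes on the series: bromo in place of chloro

The source may hold more compounds than are shown below. What is called first, only, known or untested is meant among the compounds shown, and "the series" means these compounds.

Measured in a physicochemical assay for lipophilicity, measured as octanol-water partition; on this read-out higher numbers stand for higher lipophilicity and lower numbers for lower lipophilicity:
compound 1 `CC(C)[C@@H]1CC[C@@H](C)C[C@H]1OC(=O)c1cccc([N+](=O)[O-])c1`: 4.78
compound 2 `COc1cccc(C(=O)O[C@@H]2C[C@H](C)CC[C@H]2C(C)C)c1`: 4.57
compound 3 `CC(C)[C@@H]1CC[C@@H](C)C[C@H]1OC(=O)c1cccc(Cl)c1`: 5.34

Compound 3 stands highest of the three, at 5.34. The next compound, compound 4 `CC(C)[C@@H]1CC[C@@H](C)C[C@H]1OC(=O)c1cccc(Br)c1`, carries bromo in place of chloro on an aromatic carbon. Within the data shown here, no measured step involves bromo, so the evidence is indirect. The nearest guides are a number 0.56 log units higher from compound 1 to compound 3 (beyond the scatter) and a number 0.77 log units higher from compound 2 to compound 3 (beyond the scatter), both of which bring in chloro. Neither exchanges one of these two groups for the other, so a smaller step is expected in this assay. The expected step is a number 0.16 log units higher from compound 3 to compound 4 (within the scatter), small, upward and within the scatter. For compound 4 the estimated value is 5.5, with an expected range of 5.2 to 5.8.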

Compound 4, partition coefficient: 5.61
The estimate for compound 4 lay 0.11 log units below the measured number, within the range that was stated.
By their numbers in this assay, from the lowest: compounds 2 and 1 (each within the scatter of the next); then compounds 3 and 4 (each within the scatter of the next).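

Bromo and chloro on this aromatic carbon are not told apart in this assay (a number 0.27 log units higher from compound 3 to compound 4 (within the scatter)). Bromo stands clear of methoxy (a number 1.04 log units higher from compound 2 to compound 4 (beyond the scatter)) and of nitro (a number 0.83 log units higher from compound 1 to compound 4 (beyond the scatter)), and the step from methoxy is the only large one among the compounds shown. Compound 3 and compound 4 therefore form one pair, separated beyond the scatter from compound 1 and compound 2.

From the compounds shown here alone, whether an amine or a carboxylic acid at this place would stand with either pair remains open. Nothing shown bears on the reason for these steps.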